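The source may hold more compounds than are shown below. What is called first, only, known or untested is meant among the compounds shown, and "the series" means these compounds.

Measured so far in a functional assay on HT-1080 cells (Homo sapiens) for antiproliferative activity, read by MTT assay, with a stated time of 72 h; a higher number here means a weaker inhibitor, a lower number a stronger inhibitor:
- compound 1 `CCOC(=O)c1cc(-c2cc(OC)c(OC)c(OC)c2)c(-c2ccc(OC)cc2)s1`: 8370 nM
- compound 2 `COc1ccc(-c2sc(C(=O)O)cc2-c2cc(OC)c(OC)c(OC)c2)cc1`: 6770 nM

The series holds only these two numbers, and compound 2 stands level with compound 1. Going by the values given here, the single measured step is a 1.2-fold lower number from compound 1 to compound 2 (0.09 log units; within the scatter), with hydrogen in place of ethyl on an oxygen next to a carbonyl group.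

The next entry is compound 3 `COc1ccc(-c2sccc2-c2cc(OC)c(OC)c(OC)c2)cc1`, which has hydrogen in place of carboxy on an aromatic carbon, next to the ring sulfur: hydrogen in place of carboxy on an aromatic carbon.

The measured step bears on this change only indirectly. Among the compounds with values here, it alters the end of the group and keeps the carbonyl, while no measured pair removes the whole group. The small size of that step therefore does not settle the size of this one. In this assay, within the data shown here, a moderate drop in the number is expected, though this direction is a judgement that no measured step supports, so the range stays wide and includes no change. The estimated change is a 2.3-fold lower number from compound 2 to compound 3 (0.35 log units; beyond the scatter). Compound 3 is estimated at 3000 nM, with an expected range of 300 nM to 12000 nM.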

Compound 3, half-maximal inhibitory concentration: 4590 nM
Estimate against measurement, compound 3: 1.5-fold (0.18 log units) below, within the range that was stated.
By their numbers in this assay, from the lowest: compounds 3, 2 and 1 (each within the scatter of the next).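

In this assay, hydrogen in place of carboxy on the aromatic carbon next to the ring sulfur gives a 1.5-fold lower number from compound 2 to compound 3 (0.17 log units; within the scatter), and hydrogen in place of ethoxycarbonyl at the same carbon gives a 1.8-fold lower number from compound 1 to compound 3 (0.26 log units; within the scatter). The earlier pair altered only the end of the group and kept the carbonyl, whereas these steps remove the whole group, and all three compounds still lie within the scatter of one another, so within this set the group at this position is not needed to hold the number at this level. The data offer no independent measurement that would explain this lack of separation.

On these data alone, whether any other group on this carbon, such as an amine, a primary amide, a bromine or a longer chain, would move the number beyond the scatter remains open. As far as these compounds go, all three compounds also carry the same 4-methoxyphenyl group, so it is equally open whether this position would stay as insensitive with a hydroxy or a fluorine in place of that methoxy.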